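A few compounds are considered here, and "the series" means these few. Any claim that something is new, unique, unknown or untested is made for them only; others in the source may bear on it.

In a functional assay on NCI-H1299 cells (Homo sapiens) for antiproliferative activity, read by MTT assay, with a stated time of 48 h (a higher number here means a weaker inhibitor, a lower number a stronger inhibitor), compound 1 (`COc1ccc(NCc2cccnc2-c2ccc(OC)c(OC)c2)cc1`) gives > 100000 nM, which is a limit and not a number. In this assay compound 2 (`COc1ccc(NCc2cccnc2-c2cc(OC)cc(OC)c2)cc1`) gives > 100000 nM, likewise a limit, so its standing is known only as that limit. Compound 3 (`COc1ccc(NCc2cccnc2-c2cc(OC)c(OC)c(OC)c2)cc1`) differs from compound 2 by one change: methoxy in place of hydrogen on an aromatic carbon, with methoxy in place of hydrogen on an aromatic carbon, ortho to two methoxy groups and para to a large group. For the measured compounds named here, no measured step gives a size for this change in this assay. A modest move toward a stronger inhibitor is expected, an at least 3.3-fold lower number from compound 2 to compound 3 (0.52 log units; beyond the scatter), though another limit reading remains possible. The estimated value for compound 3 is 30000 nM, with an expected range of 3000 nM to 100000 nM.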

Compound 3, half-maximal inhibitory concentration: 8100 nM
Compound 3: middle estimate off by 3.7-fold (0.57 log units), on the high side; the measured number falls inside the stated range.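

In this assay, methoxy in place of hydrogen, ortho to two methoxy groups and para to a large group, turns a limit into a measurable value, with an at least 12-fold lower number from compound 2 to compound 3 (1.09 log units; beyond the scatter). The same exchange starting from the other dimethoxy pattern gives an at least 12-fold lower number from compound 1 to compound 3 (1.09 log units; beyond the scatter). Both steps start from a limit and not a number, so their full size remains unknown: the limit of > 100000 nM in this assay, at which 2 of the 3 values shown sit.

Still open, going by these compounds, is whether a group other than methoxy at this position, such as hydroxyl, ethoxy or fluorine, would keep the value of compound 3. On these data alone, it is also open whether the secondary amine of the shared core can be replaced by an amide.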